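Methoxy for Chloro on a Weakly Inhibiting Benzylsulfanyl Series

A few compounds are considered here, and "the series" means these few. Any claim that something is new, unique, unknown or untested is made for them only; others in the source may bear on it.

Measured compounds:
compound 1 `Cc1cc(Nc2cc(-c3ccccc3)[nH]n2)n2nc(SCc3ccc(Cl)cc3)nc2n1`, 31800 nM
compound 2 `Cc1cc(Nc2cc(-c3cccs3)[nH]n2)n2nc(SCc3ccc(Br)cc3)nc2n1`, 38700 nM
compound 3 `Cc1ccc(Cn2ccc(Nc3cc(C)nc4nc(SCc5ccc(Br)cc5)nn34)n2)cc1`, > 50000 nM

The assay in question is an ADME assay on GES1 cells (Homo sapiens) for inhibition, read by MTT assay, with a stated time of 72 h; on this read-out higher numbers stand for weaker inhibition and lower numbers for stronger inhibition. Compound 1 is the compound followed here; in this assay compound 1 gives 31800 nM. Compound 2 gives 38700 nM, and the two numbers lie within the usual scatter of each other, so no order between compound 1 and compound 2 can be read from them. Among the compounds with values here, compound 3 gives only a limit of the assay, > 50000 nM, and not a number; it is the one value at the limit of > 50000 nM in this assay, at which 1 of the 3 values shown sits. Within the data shown here, no two of the measured compounds differ in a single place, so no measured step is available.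

Compound 4 `COc1ccc(CSc2nc3nc(C)cc(Nc4cc(-c5ccccc5)[nH]n4)n3n2)cc1` is not yet measured. It differs from compound 1 in one place:

methoxy in place of chloro on an aromatic carbon

Among the measured compounds shown here, with no measured step of this kind to lean on, the change from compound 1 to compound 4 is expected to move the number by no more than the scatter. The step from compound 1 to compound 4 is therefore estimated as a 1.1-fold higher number from compound 1 to compound 4 (0.04 log units; within the scatter). On that basis compound 4 is expected to give about 35000 nM, within a range from 15000 nM to 80000 nM.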

Compound 4, half-maximal inhibitory concentration: 28200 nM
The estimate for compound 4 lay 1.2-fold (0.09 log units) above the measured number; measured number inside the range.
By their numbers in this assay, from the lowest: compounds 4, 1 and 2 (each within the scatter of the next). At a limit, above all of these: compound 3.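

In this assay, within the data shown here, methoxy in place of chloro, on an aromatic carbon of a six-membered aromatic ring of carbon only and para to a large group, gives a 1.1-fold lower number from compound 1 to compound 4 (0.05 log units; within the scatter); this is the first measured step, and it does not separate the two compounds. The hydrogen-bond acceptor that enters with methoxy, on a (4-methoxybenzyl)sulfanyl group in place of (4-chlorobenzyl)sulfanyl, therefore leaves the number within the scatter in this one pair. Nothing measured here speaks to why this exchange leaves the number where it is.

As far as these compounds go, whether an amine, a carboxylic acid or a longer chain such as ethoxy at this same place would move the number beyond the scatter remains open. From the compounds shown here alone, it is also open whether methoxy in place of bromo would read the same way on compound 2 and compound 3, which carry different groups on the other side of the shared core.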